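Swapping the para substituent: from hydroxy to nitro

The compounds below may be only part of what the source reports. "The series", "measured", "known", "first", "only" and "open" are said of these compounds alone.

Compound 1, `O=c1cc(CNCc2ccc(Br)cc2)oc2ccc(O)c(O)c12`: in an ADME assay on Huh-7 cells (Homo sapiens) for cytotoxicity (on this read-out higher numbers stand for lower toxicity in this test and lower numbers for higher toxicity in this test), compound 1 gives > 100000 nM, a limit of the assay.
Compound 2, `O=c1cc(CNCc2ccc(O)cc2)oc2ccc(O)c(O)c12`: in this assay compound 2 gives 62700 nM.

Among the measured compounds shown here, compound 2 holds the only number measured; the other result is a limit (the limit of > 100000 nM in this assay, at which 1 of the 2 values shown sits). The change to compound 3, `O=c1cc(CNCc2ccc([N+](=O)[O-])cc2)oc2ccc(O)c(O)c12`, is nitro in place of hydroxy on an aromatic carbon. For the measured compounds named here, the one measured step on this position, an at least 1.5-fold lower number from compound 1 to compound 2 (0.20 log units; that floor lies within the scatter), is small and lies within the scatter, so no step beyond the scatter is expected in this assay. The expected step is a 1.1-fold higher number from compound 2 to compound 3 (0.05 log units; within the scatter). Compound 3 is therefore estimated at 70000 nM, within 25000 nM to 200000 nM.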

Compound 3, half-maximal cytotoxic concentration: 73300 nM
The estimate for compound 3 lay 1.0-fold (0.02 log units) below the measured number; measured number inside the range.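

In this assay, nitro in place of hydroxy gives a 1.2-fold higher number from compound 2 to compound 3 (0.07 log units; within the scatter), so at this position a larger group with no hydrogen-bond donor cannot be told apart from hydroxy. The comparison with bromo gives an at least 1.3-fold lower number from compound 1 to compound 3 (0.13 log units; that floor lies within the scatter), and that floor also offers no separation beyond the scatter. The true size of this step cannot be read because compound 1 stands at a limit: the limit of > 100000 nM in this assay, at which 1 of the 3 values shown sits.

As far as these compounds go, whether an amine, a carboxylic acid or a longer chain at this position would shift the number beyond the scatter remains open.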